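This account rests on a few compounds, and the source may have more. Where it says the series, first, only, none or still open, it means among the compounds named here.

Of the compounds shown here, three that share one core have been tested in a functional assay on HEK293 cells (Homo sapiens) for cytotoxicity; a lower number here means that less compound is tolerated, a higher number that more compound is tolerated. Compound 1 `COc1ccc([C@H]2CC(=O)N(c3cccc(O)c3)C2)cc1OC1CCCC1`, with a 3-hydroxyphenyl on the amide-type nitrogen in a ring, gives > 10000 nM, which is a limit and not a number. Compound 2 `COc1ccc([C@H]2CC(=O)N(c3cc(N)cc(N)c3)C2)cc1OC1CCCC1`, with a 3,5-diaminophenyl in that place, gives > 10000 nM, again a limit. Compound 3 `COc1ccc([C@H]2CC(=O)N(c3ccccc3N)C2)cc1OC1CCCC1`, with a 2-aminophenyl there, gives > 10000 nM, also a limit. Compound 3 therefore stands with the other two, at the limit of > 10000 nM in this assay, at which 3 of the 3 values shown sit.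

The untested compound 4 `COc1ccc([C@H]2CC(=O)N(c3cc(N)cc(F)c3)C2)cc1OC1CCCC1` differs from compound 3 at this one place: 3-amino-5-fluorophenyl in place of 2-aminophenyl on an amide-type nitrogen in a ring. In words, it has 3-amino-5-fluorophenyl in place of 2-aminophenyl.

The measured steps that bear on this change are a step that the two limits leave unreadable from compound 1 to compound 2, a step that the two limits leave unreadable from compound 1 to compound 3 and a step that the two limits leave unreadable from compound 2 to compound 3. All three alter the group on the same nitrogen, and none has a readable size. Among the measured compounds shown here, none of these changes brought a value off the limit, but no tested compound carries a fluorine, so the expectation remains uncertain. No step beyond the scatter is expected, and the estimated step is a step that the limit leaves unreadable from compound 3 to compound 4. For compound 4, the expected value is 15000 nM, with an estimated range from 6000 nM to 40000 nM.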

Compound 4, half-maximal cytotoxic concentration: > 10000 nM
Compound 4 was reported as a limit; the forecaster's own chance of this, stated with the estimate: 85%; the middle value lies beyond the limit too.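

In this assay compound 4 gives > 10000 nM, which is a limit and not a number. No step from compound 1, compound 2 or compound 3 to compound 4 can be read, because all four compounds share one limit: the limit of > 10000 nM in this assay, at which 4 of the 4 values shown sit.

The compounds shown leave open how much of each is actually tolerated, and whether any group on that nitrogen would bring a value off the limit.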